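From 2-nitrophenyl to pyridin-4-yl on a shared core

The source may report more compounds than this note shows. Statements on the series, on what has been measured and on what is new or still open speak of the compounds shown alone.

- compound 1 `CC(=O)N1N=C(c2ccc3ccccc3c2)OC1c1ccccc1`: 2.11 ug/mL
- compound 2 `CC(=O)N1N=C(c2ccc3ccccc3c2)OC1c1ccc(Cl)cc1`: 1.88 ug/mL
- compound 3 `CC(=O)N1N=C(c2ccc3ccccc3c2)OC1c1ccccc1[N+](=O)[O-]`: 12.3 ug/mL

In a functional assay on HepG2 cells (Homo sapiens) for antiproliferative activity, read by MTT assay, with a stated time of 48 h (on this read-out higher numbers stand for weaker inhibition and lower numbers for stronger inhibition), compound 3 stands highest of the three at 12.3 ug/mL, which makes it the weakest inhibitor so far. The next compound, compound 4 `CC(=O)N1N=C(c2ccc3ccccc3c2)OC1c1ccncc1`, carries pyridin-4-yl in place of 2-nitrophenyl on a saturated ring carbon.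

Among the compounds with values here, three measured steps bear on this change. Adding a nitro group gave a 5.8-fold higher number from compound 1 to compound 3 (0.77 log units; beyond the scatter), and 2-nitrophenyl in place of 4-chlorophenyl gave a 6.5-fold higher number from compound 2 to compound 3 (0.82 log units; beyond the scatter); both are modest. Chloro in place of hydrogen gave a 1.1-fold lower number from compound 1 to compound 2 (0.05 log units; within the scatter), which lies within the scatter. Compound 4 has no nitro group, so the nearer guides are compound 1 at 2.11 ug/mL and compound 2 at 1.88 ug/mL. Within the data shown here, no measured compound has a hetero atom in this aromatic ring, so the return towards those values may be only partial.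

A modest step to a lower number is expected, estimated as a 2.7-fold lower number from compound 3 to compound 4 (0.44 log units; beyond the scatter). For compound 4 the estimate is 4.5 ug/mL, with an expected range of 1.5 ug/mL to 14 ug/mL.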

Compound 4, half-maximal inhibitory concentration: 2.17 ug/mL
For compound 4 the middle estimate is 2.1-fold (0.32 log units) above the measured one, and the stated range covers the measured number.
By their numbers in this assay, from the lowest: compounds 2, 1 and 4 (each within the scatter of the next); then compound 3.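

In this assay, pyridin-4-yl in place of 2-nitrophenyl on the saturated ring carbon gave a 5.7-fold lower number from compound 3 to compound 4 (0.75 log units; beyond the scatter) and so brought the number back into the company of the compounds without a nitro group. Within the data shown here, the comparison also shows for the first time that this position accepts a hetero atom in the aromatic ring with no change beyond the scatter: the replacement of phenyl gave a 1.0-fold higher number from compound 1 to compound 4 (0.01 log units; within the scatter) and the replacement of 4-chlorophenyl gave a 1.2-fold higher number from compound 2 to compound 4 (0.06 log units; within the scatter) in the same read-out. No measurement at hand explains these steps.

Since 2-nitrophenyl is the only nitro-bearing ring shown, it remains open whether the higher number of compound 3 goes with the nitro group itself or with where it sits. Going by these compounds, it is also open whether an amine, a methoxy group or a carboxylic acid on the phenyl ring would stay level with compound 1.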